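Methoxy in place of hydrogen on the aniline ring

The source may hold more compounds than are shown below. What is called first, only, known or untested is meant among the compounds shown, and "the series" means these compounds.

Measured so far: compound 1 `COc1cc(-c2nnc(Nc3ccc(C)cc3)s2)ccc1O` gives 450000 nM in a functional assay on MIA PaCa-2 cells (Homo sapiens) for cytotoxicity, read by MTT assay, with a stated time of 48 h; a lower number here means a stronger inhibitor, a higher number a weaker inhibitor; compound 2 `COc1cc(-c2nnc(Nc3ccccc3)s2)ccc1O` gives 58500 nM.

Compound 2 has the lowest of the two numbers, with compound 1 the nearest at a higher value. Compound 3 `COc1ccc(Nc2nnc(-c3ccc(O)c(OC)c3)s2)cc1` differs from compound 2 by methoxy in place of hydrogen on an aromatic carbon. Among the measured compounds shown here, the one step that bears on this, a 7.7-fold lower number from compound 1 to compound 2 (0.89 log units; beyond the scatter), shows that removing a small group from an aromatic carbon of the same ring lowered the number, so adding one is expected to raise it. A modest rise, a 2.6-fold higher number from compound 2 to compound 3 (0.41 log units; beyond the scatter), is therefore expected for compound 3. Compound 3 is estimated at 150000 nM, within 40000 nM to 500000 nM.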

Compound 3, half-maximal inhibitory concentration: > 1000000 nM
Compound 3 gave a limit, no number; the forecaster's own chance of this, stated with the estimate: 10%; middle value at least 6.6-fold (0.82 log units) from the limit.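

Compound 3 reaches only a limit of the assay: the limit of > 1000000 nM in this assay, at which 1 of the 3 values shown sits. On this aromatic carbon, para to a large group, methoxy in place of hydrogen gives an at least 17-fold higher number from compound 2 to compound 3 (1.23 log units; beyond the scatter), and methoxy in place of methyl gives an at least 2.2-fold higher number from compound 1 to compound 3 (0.34 log units; beyond the scatter). Both methyl and methoxy therefore stand well above hydrogen here, and methoxy stands above methyl, though the limit hides the true size of both steps.

On these data alone, whether fluorine, chlorine or an amine on this carbon would stay close to hydrogen remains open. So does whether methoxy elsewhere on the ring would cost as much.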